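Swapping the Aryl Group on a Shared Core

This account rests on a few compounds, and the source may have more. Where it says the series, first, only, none or still open, it means among the compounds named here.

Compound 1: `O=Cc1ccc(-c2cn3ccnc3c(-c3ccc4ncn(C5CCCCC5)c4c3)n2)cc1` gives 25% in a functional assay on RXF 393 cells (Homo sapiens) for inhibition, read by sulforhodamine B assay, with a stated time of 48 h, tested at 10 uM; a lower number here means less inhibition, a higher number more inhibition at the concentration tested (going by the name of the read-out).
Compound 2: `Brc1ccc(-c2cn3ccnc3c(-c3ccc4ncn(C5CCCCC5)c4c3)n2)cc1` gives 34% in this assay.

In this assay compound 2 stands highest of the two numbers shown, but its only neighbour is compound 1, and the step of a number 9 percentage points higher from compound 1 to compound 2 (within the scatter) lies within the scatter, so the two values cannot be told apart. Compound 3, `Fc1ccccc1-c1cn2ccnc2c(-c2ccc3ncn(C4CCCCC4)c3c2)n1`, has not yet been measured. It differs from compound 2 in one place: 2-fluorophenyl in place of 4-bromophenyl on an aromatic carbon. Going by the values given here, no measured step covers this change; the single step known, bromo in place of formyl, stayed within the scatter. With nothing pointing either way, the expected step is a number 6 percentage points lower from compound 2 to compound 3 (within the scatter), a shift not beyond the scatter. Compound 3 is therefore estimated to give 28% in this assay, with a range from 10% to 50%.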

Compound 3, a percentage reported as inhibition, at one concentration (the size of the read-out at that concentration, not a potency): 12.3%
Compound 3: the middle estimate sits 15.7 percentage points above what was measured, and the stated range covers the measured number.
By their numbers in this assay, from the lowest: compound 3; then compounds 1 and 2 (each within the scatter of the next).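

Changing the aryl group at this position can move the number measurably in this assay: 2-fluorophenyl in place of 4-bromophenyl gives a number 21.7 percentage points lower from compound 2 to compound 3 (beyond the scatter), and 2-fluorophenyl in place of 4-formylphenyl gives a number 12.7 percentage points lower from compound 1 to compound 3 (beyond the scatter). Going by these compounds alone, the earlier change, bromo in place of formyl, gave only a number 9 percentage points higher from compound 1 to compound 2 (within the scatter), so compound 3 is the first to stand apart from the others, and it gives the lowest number of the three. No available evidence accounts for this fall.

Compound 3 differs from compound 1 and compound 2 in both the substituent and its place on the phenyl ring, so the effects of these two changes remain unseparated; 4-fluorophenyl and 2-bromophenyl would help to tell them apart. As far as these compounds go, how an amine or a carboxylic acid on the phenyl ring would fare also remains open.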